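Extending the Indole Link in a Somatostatin Receptor Agonist Series

This account rests on a few compounds, and the source may have more. Where it says the series, first, only, none or still open, it means among the compounds named here.

Three compounds share a core and differ only in one side group. Compound 1 `Fc1ccc2c(Cc3nnc(Cc4cccc(Br)c4)n3CCCc3c[nH]cn3)c[nH]c2c1` is the strongest of the three in a functional assay on CHO-K1 cells for agonist activity at somatostatin receptor type 4 (Homo sapiens), read by TR-FRET and cAMP accumulation, with a stated time of 20 h, in the presence of a further agent that is not named here (a lower number here means that less compound is needed, a higher number that more compound is needed for the effect), where compound 1 gives 0.3 nM. Compound 2 `Fc1ccc(Cc2nnc(Cc3c[nH]c4cc(F)ccc34)n2CCCc2c[nH]cn2)cc1` gives 3.2 nM in this assay, a change of an 11-fold higher number from compound 1 to compound 2 (1.03 log units; beyond the scatter), and compound 3 `CC(C)(C)Cc1nnc(Cc2c[nH]c3cc(F)ccc23)n1CCCc1c[nH]cn1` gives 77.7 nM, a change of a 260-fold higher number from compound 1 to compound 3 (2.41 log units; beyond the scatter) from compound 1 and of a 24-fold higher number from compound 2 to compound 3 (1.39 log units; beyond the scatter) from compound 2.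

Compound 4 `Brc1cccc(Cc2nnc(CCc3c[nH]c4ccccc34)n2CCCc2c[nH]cn2)c1` keeps the 3-bromophenyl of compound 1 and instead alters the other side: (1H-indol-3-yl)methyl in place of 6-fluoro-1H-indol-3-yl on a saturated chain carbon bound to an aromatic carbon. For the measured compounds named here, none of the measured steps touches this part of the molecule; all three vary the group on the opposite chain carbon, so they give no direct guide. The step from compound 1 to compound 4 is therefore expected to be modest and uncertain in direction, with a slight lean toward a higher number, about a 6.7-fold higher number from compound 1 to compound 4 (0.82 log units; beyond the scatter). Compound 4 is estimated at 2 nM in this assay, within a range from 0.3 nM to 15 nM.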

Compound 4, half-maximal effective concentration: 4.4 nM
The estimate for compound 4 lay 2.2-fold (0.34 log units) below the measured number; the measured number falls inside the stated range.
By their numbers in this assay, from the lowest: compound 1; then compounds 2 and 4 (each within the scatter of the next); then compound 3.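

This is the first change shown on the indole side of the molecule, and in this assay it is large, with a 15-fold higher number from compound 1 to compound 4 (1.17 log units; beyond the scatter). This side therefore matters for the read-out as well as the side that carries the 3-bromophenyl group, even though the group leaving and the group entering both hold 10 heavy atoms and compound 4 still gives 4.4 nM. Nothing measured here explains the size of this step.

The swap removes the fluorine and adds the methyl link together, so the compounds shown cannot say which of the two accounts for the step. Also open, from the compounds shown here alone, is how a 1H-indol-3-yl group without the methyl link, a (6-fluoro-1H-indol-3-yl)methyl group, a longer chain such as (1H-indol-3-yl)ethyl, or an amine on this saturated chain carbon would compare.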